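The source may report more compounds than this note shows. Statements on the series, on what has been measured and on what is new or still open speak of the compounds shown alone.

Among the compounds with values here, compound 2 `C[C@@H]1CN(c2cccc3c2C[C@H](CN(C)[C@H]2CCCc4cccnc42)NC3)C[C@H](C)N1C` holds the higher of the two numbers measured so far in an ADME assay on microsomes from liver (Mus musculus) for metabolic stability, read by LC-MS, with a stated time of 10 min (a higher number here means that more of the compound is left, a lower number that less of the compound is left), where compound 2 gives 39.6%. Compound 1 `CN(C[C@H]1Cc2c(cccc2N2CCN3CCC[C@@H]3C2)CN1)[C@H]1CCCc2cccnc21` gives 36.7% in this assay, and the gap between them, a number 2.9 percentage points higher from compound 1 to compound 2 (within the scatter), does not rise above the noise of repeated runs. Compound 3 `CN(C[C@H]1Cc2c(cccc2N2CCN3CCC[C@H]3C2)CN1)[C@H]1CCCc2cccnc21` has not yet been measured. It differs from compound 2 in one place: a group of 9 heavy atoms (7 carbon, 2 nitrogen; one five-membered non-aromatic ring with 1 hetero atom, one six-membered non-aromatic ring with 2 hetero atoms) in place of a group of 9 heavy atoms (7 carbon, 2 nitrogen; one six-membered non-aromatic ring with 2 hetero atoms), on an aromatic carbon. Apart from the handedness of one stereocentre in the entering group, this is the reverse of the only step measured so far, the one from compound 1 to compound 2, which was small. The expected step is therefore also small, if anything pointing back toward the value of compound 1. For compound 3 the estimate in this assay is 36%, with a range from 24% to 48%. That estimate means an expected change of a number 3.6 percentage points lower from compound 2 to compound 3 (within the scatter), within the scatter.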

Compound 3, percent of the compound remaining: 40.1%
Estimate against measurement, compound 3: 4.1 percentage points below, and the stated range covers the measured number.
By their numbers in this assay, from the lowest: compounds 1, 2 and 3 (each within the scatter of the next).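

The pair of compound 1 and compound 3 tests handedness alone at this saturated ring carbon, for one reason: the fact that compounds 1 and 3 differ only in the configuration as drawn. In this assay that inversion gives a number 3.4 percentage points higher from compound 1 to compound 3 (within the scatter), so the handedness of this centre in the entering group does not separate the two compounds here. The change of 3,4,5-trimethylpiperazin-1-yl for the group with a five-membered and a six-membered ring, on the same aromatic carbon, gives a number 0.5 percentage points higher from compound 2 to compound 3 (within the scatter), so with either handedness this group stays level with the trimethylpiperazine within the scatter.

From the compounds shown here alone, all three compounds carry groups of the same size with the same atoms at this position, so it remains open whether a smaller or different group, such as dimethylamino or morpholine, would give a clearly different number. Why so much of each compound is lost also remains open.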